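A few compounds are considered here, and "the series" means these few. Any claim that something is new, unique, unknown or untested is made for them only; others in the source may bear on it.

Of the compounds shown here, two have so far been measured in a functional assay on L6 cells (Rattus norvegicus) for inhibition; on this read-out higher numbers stand for weaker inhibition and lower numbers for stronger inhibition. Compound 1 (`CC(C)c1c(C(=O)N(C)Cc2ccccc2)nn(-c2ccc(F)cc2)c1CC[C@@H](O)C[C@@H](O)CC(=O)O`) gives 2870 nM, and compound 2 (`CC(C)c1c(C(=O)N(C)Cc2ccccc2)nn(-c2ccc(F)cc2)c1OC[C@@H](O)C[C@@H](O)CC(=O)O`) gives 6720 nM, the higher of the two numbers and therefore the weaker inhibition. The next compound, compound 3 (`CC(C)c1c(C(=O)NCc2cccc(F)c2F)nn(-c2ccc(F)cc2)c1OC[C@@H](O)C[C@@H](O)CC(=O)O`), keeps the side chain of compound 2 and alters the amide: (2,3-difluorobenzyl)amino in place of benzyl(methyl)amino on a carbonyl carbon. In other words, (2,3-difluorobenzyl)amino stands in place of benzyl(methyl)amino on a carbonyl carbon. For the measured compounds named here, only one measured step is available, a 2.3-fold higher number from compound 1 to compound 2 (0.37 log units; beyond the scatter). It is modest, but it concerns the chain on an aromatic carbon and not the amide, so it bears on this change only as a rough guide to how far a single change has moved the number in this series. Going by the values given here, no measured pair varies the amide, and the data therefore give no direction for the change. No shift beyond the scatter is expected in this assay, though the uncertainty is wide in both directions. The estimated step is a 1.1-fold lower number from compound 2 to compound 3 (0.05 log units; within the scatter). For compound 3 the expected value is 6000 nM, with an estimated range from 1500 nM to 22000 nM.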

Compound 3, half-maximal inhibitory concentration: 120 nM
Compound 3: the middle estimate sits 50-fold (1.70 log units) above what was measured; the measured number lies below the stated range.
By their numbers in this assay, from the lowest: compound 3; then compound 1; then compound 2.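

In this assay the group on the carbonyl carbon proves to be a far stronger lever than the chain on the aromatic carbon: the amide change gives a 56-fold lower number from compound 2 to compound 3 (1.75 log units; beyond the scatter) and the chain change gave only a 2.3-fold higher number from compound 1 to compound 2 (0.37 log units; beyond the scatter) in the opposite direction of number. For the compounds shown here, the position is therefore highly sensitive to substitution, and going from benzyl(methyl)amino to (2,3-difluorobenzyl)amino recovers strong inhibition on the side chain of compound 2, which had the highest number so far. This single step changes several things at once, as the methyl group leaves while an amide hydrogen and two fluorine atoms enter, and nothing available explains why the number falls so sharply.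

The compounds shown leave open how much of the step belongs to the amide hydrogen and how much to the fluorine atoms, a question that a plain benzylamino group and a (2,3-difluorobenzyl)(methyl)amino group on the same carbonyl carbon would separate. From the compounds shown here alone, it also remains open whether (2,3-difluorobenzyl)amino would act as strongly alongside the 6-carboxy-3,5-dihydroxyhexyl chain of compound 1.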